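Replacing the anilino end of compound 3 with an ester chain

The source may hold more compounds than are shown below. What is called first, only, known or untested is meant among the compounds shown, and "the series" means these compounds.

Measured compounds in an assay on HEK293 cells for displacement of a labelled ligand from prostaglandin D2 receptor 2 (Homo sapiens); a higher number here means a weaker inhibitor, a lower number a stronger inhibitor:
- compound 1, `O=C(O)Cn1c(SCCCCOc2ccccc2)nc2ccccc21`, 1400 nM
- compound 2, `O=C(O)Cn1c(SCCc2ccccc2)nc2ccccc21`, 881 nM
- compound 3, `O=C(O)Cn1c(SCCNc2ccccc2)nc2ccccc21`, 7690 nM

Compound 3 stands at the highest number of the three in this assay, beyond the scatter from both others: compound 1 sits nearer and compound 2 furthest. Among the compounds with values here, the one step that reaches compound 3 is an 8.7-fold higher number from compound 2 to compound 3 (0.94 log units; beyond the scatter); it shows that the anilino end, compared with a phenyl end on the same chain position, goes with a clearly weaker inhibitor.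

Compound 4, `CCOC(=O)CCCSc1nc2ccccc2n1CC(=O)O`, differs from compound 3 by (ethoxycarbonyl)methyl in place of anilino on a saturated chain carbon, two bonds along the chain from a sulfur. Within the data shown here, no measured step removes the aromatic ring from this chain and puts an ester in its place, so the only bearing comes from the fact that each of the three measured compounds carries a six-membered aromatic ring at the chain end and that compound 3, the only one with the anilino, is the weakest. Going by these compounds, removing the anilino may therefore recover part of what was lost in the step from compound 2 to compound 3, but whether the ester chain supports binding on its own is untested. The estimate for compound 4 in this assay is 3000 nM, with a range from 700 nM to 13000 nM, which means an expected step of a 2.6-fold lower number from compound 3 to compound 4 (0.41 log units; beyond the scatter).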

Compound 4, half-maximal inhibitory concentration: 4410 nM
Compound 4: the middle estimate sits 1.5-fold (0.17 log units) below what was measured; low and high end bracket the measured number.
By their numbers in this assay, from the lowest: compounds 2 and 1 (each within the scatter of the next); then compounds 4 and 3 (each within the scatter of the next).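

In this assay the step of a 1.7-fold lower number from compound 3 to compound 4 (0.24 log units; within the scatter) lies within the scatter, so this assay does not separate the (ethoxycarbonyl)methyl end, which has no ring, from the anilino end, which has a six-membered aromatic ring of carbon only. The comparison with the two stronger inhibitors is clearer: the step of a 5.0-fold higher number from compound 2 to compound 4 (0.70 log units; beyond the scatter) and the step of a 3.2-fold higher number from compound 1 to compound 4 (0.50 log units; beyond the scatter) both lie beyond the scatter, so compound 4 is a weaker inhibitor than the phenyl compound and the phenoxymethyl compound. Compound 3 keeps an aromatic ring and still stands with compound 4, which shows that an aromatic ring at this chain end is not enough on its own for the lower numbers seen with compound 1 and compound 2, and no measurement offered here explains the difference in these values.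

The compounds shown leave open how a free carboxylic acid or a primary amide would compare with the ethyl ester on this same chain, which would show whether the ester matters at all. They also leave open whether a plain hexyl chain or a benzyl ester would fall with compound 4 or nearer compound 2.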